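From a carboxylic acid to a pyrrolidin-1-yl amide

A few compounds are considered here, and "the series" means these few. Any claim that something is new, unique, unknown or untested is made for them only; others in the source may bear on it.

Compound 1 `COc1cc2c(cc1OC)C(CC(=O)O)CC2` is the free acid of the set. In a functional assay on the whole organism (strain Wistar) for inhibition, with Rattus norvegicus as the target, read by paw edema, with stated times of 60 min and 24 h, at a dose of 100 mg/kg by the oral route (a higher number here means more inhibition at the dose given (going by the name of the read-out), a lower number less inhibition), compound 1 gives 26.7%, the lowest of the three numbers measured: compound 2 `CCNC(=O)CC1CCc2cc(OC)c(OC)cc21` gives 33.3%, and compound 3 `CCCCCNC(=O)CC1CCc2cc(OC)c(OC)cc21` gives 46.7%. The step of a number 6.6 percentage points higher from compound 1 to compound 2 (within the scatter) lies within the scatter, whereas a number 20 percentage points higher from compound 1 to compound 3 (beyond the scatter) goes beyond it, as does a number 13.4 percentage points higher from compound 2 to compound 3 (beyond the scatter).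

Compound 4 `COc1cc2c(cc1OC)C(CC(=O)N1CCCC1)CC2` has not yet been measured in this assay. It differs from compound 1 in one place: pyrrolidin-1-yl in place of hydroxy on a carbonyl carbon. Both measured steps from compound 1 bear on this change, since each likewise puts a nitrogen group in place of the hydroxy on the carbonyl carbon: a number 6.6 percentage points higher from compound 1 to compound 2 (within the scatter) stayed within the scatter, while a number 20 percentage points higher from compound 1 to compound 3 (beyond the scatter) was a modest rise. A modest rise is therefore expected in this assay for compound 4, estimated as a number 13.3 percentage points higher from compound 1 to compound 4 (beyond the scatter). Compound 4 is expected to give about 40%, within a range from 27% to 53%.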

Compound 4, a percentage reported as inhibition, in the whole organism at one dose (the size of the read-out at that dose, not a potency): 33.3%
Beside the measured number, compound 4's estimate is 6.7 percentage points above it; the range from low to high includes it.
By their numbers in this assay, from the lowest: compounds 1, 2 and 4 (each within the scatter of the next); then compound 3.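

In this assay, among these compounds, the pyrrolidin-1-yl group brings a ring onto the carbonyl carbon for the first time, yet the step to it is only a number 6.6 percentage points higher from compound 1 to compound 4 (within the scatter) and so does not separate it from the free acid. Among the amides, no change at the digits printed from compound 2 to compound 4 (within the scatter) shows this ring level with ethylamino, whereas a number 13.4 percentage points lower from compound 3 to compound 4 (beyond the scatter) sets it apart from pentylamino. A nitrogen group in place of hydroxy is therefore not enough on its own: of the three amides only compound 3 stands clear of compound 1, and compound 2 and compound 4 go against any general rise.

From the compounds shown here alone, whether a piperidin-1-yl ring or a hexylamino chain on this carbonyl carbon would match compound 3 stays open. Nothing available here gives a reason for these differences.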